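Changing the Amide Aryl Group: Compound 3 to Compound 4

The compounds below may be only part of what the source reports. "The series", "measured", "known", "first", "only" and "open" are said of these compounds alone.

Three compounds share one core and differ only in the aryl group on an amide-type nitrogen. Compound 1 `Cc1ccc(NC(=O)COc2ccc3cc(/C=C4/SC(=O)NC4=O)ccc3c2)cc1` carries 4-methylphenyl there, and in an assay on isolated protein for inhibition of histone deacetylase 8 (Homo sapiens), with a stated time of 1 h (a lower number here means a stronger inhibitor, a higher number a weaker inhibitor), compound 1 gives 9000 nM. Compound 2 `O=C(COc1ccc2cc(/C=C3/SC(=O)NC3=O)ccc2c1)Nc1ccccn1` carries pyridin-2-yl; in this assay compound 2 gives only a limit of the assay, > 50000 nM. Compound 3 `O=C(COc1ccc2cc(/C=C3/SC(=O)NC3=O)ccc2c1)Nc1cccc(C(F)(F)F)c1` carries 3-(trifluoromethyl)phenyl; in this assay compound 3 likewise gives only a limit, > 50000 nM. Both changes away from compound 1 weakened inhibition: an at least 5.5-fold higher number from compound 1 to compound 2 (0.74 log units; beyond the scatter) and an at least 5.5-fold higher number from compound 1 to compound 3 (0.74 log units; beyond the scatter). The step that the two limits leave unreadable from compound 2 to compound 3, since the limit of > 50000 nM in this assay, at which 2 of the 3 values shown sit, hides where the two compounds at the limit truly sit. Compound 3 thus stands at the weak end of what is shown, without a measurable number.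

Compound 4 `O=C(COc1ccc2cc(/C=C3/SC(=O)NC3=O)ccc2c1)Nc1c(F)cc(F)cc1Br` differs from compound 3 by one change: 2-bromo-4,6-difluorophenyl in place of 3-(trifluoromethyl)phenyl on an amide-type nitrogen. Going by the values given here, no measured step covers a halogenated phenyl of this kind, so the expectation rests on the two steps from compound 1, both of which carried substituted aryl amides to the limit. Compound 4 is therefore expected to remain weak, with an at least 1.2-fold lower number from compound 3 to compound 4 (0.09 log units; that floor lies within the scatter) in this assay amounting to no change beyond the scatter. The estimate for compound 4 is 40000 nM, with a range from 9000 nM to 150000 nM, and a good chance the assay again reports only a limit.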

Compound 4, half-maximal inhibitory concentration: > 50000 nM
Compound 4 gave a limit, no number; the forecaster's own chance of this, stated with the estimate: 60%; middle value at least 1.2-fold (0.09 log units) from the limit.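

In this assay, a third aryl group on the amide-type nitrogen, 2-bromo-4,6-difluorophenyl, also compares poorly with 4-methylphenyl, with an at least 5.5-fold higher number from compound 1 to compound 4 (0.74 log units; beyond the scatter). Compound 1 therefore remains the only compound shown with a readable number, and the loss now extends to a phenyl ring carrying bromine and fluorine as well as to pyridin-2-yl and 3-(trifluoromethyl)phenyl. The steps among compound 2, compound 3 and compound 4 cannot be read, so no order can be given for these three groups, since all three compounds sit at one boundary: the limit of > 50000 nM in this assay, at which 3 of the 4 values shown sit.

The compounds shown leave open whether the methyl group of compound 1 matters, which plain phenyl, 4-ethylphenyl or 4-methoxyphenyl at this nitrogen could test. They also leave open how far below compound 1 the three compounds at the limit truly lie.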